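Two ureas and amides at the assay limit

This account rests on a few compounds, and the source may have more. Where it says the series, first, only, none or still open, it means among the compounds named here.

Measured in a functional assay on HeLa cells (Homo sapiens) for inhibition, read by MTT assay, with a stated time of 72 h; a lower number here means a stronger inhibitor, a higher number a weaker inhibitor:
compound 1 `O=C(Nc1ccc(Oc2ncnc3[nH]ncc23)cc1)c1ccc(Br)cc1` gives > 10000 nM (a limit)
compound 2 `O=C(Nc1ccc(Oc2ncnc3[nH]ncc23)cc1)NC1CCCCC1` gives > 10000 nM (a limit)

In this assay compound 2 gives > 10000 nM as a limit, not a number. Going by the values given here, it therefore has no exact position, and the whole series so far is described by the limit of > 10000 nM in this assay, at which 2 of the 2 values shown sit, and nothing finer.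

The next compound, compound 3 `O=C(Nc1ccc(Oc2ncnc3[nH]ncc23)cc1)Nc1cccc(F)c1`, keeps the shared core and the carbonyl of compound 2 but has 3-fluorophenyl in place of cyclohexyl on an amide-type nitrogen as its one difference. The same change can be read as cyclohexylamino to (3-fluorophenyl)amino.

Among the compounds with values here, the only measured step that bears on this is a step that the two limits leave unreadable from compound 1 to compound 2 and it offers no size to carry over. Neither direction is established, so the expectation in this assay is for another weak compound, with only a modest gain in strength possible. The estimated a number no higher from compound 2 to compound 3 (the limit leaves the size open) is correspondingly uncertain. Compound 3 is estimated at 10000 nM with an expected range of 2500 nM to 30000 nM and may well report only a limit.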

Compound 3, half-maximal inhibitory concentration: > 10000 nM
Compound 3: a limit, no number; the forecaster's own chance of this, stated with the estimate: 55%; the middle value lies on the limit itself.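

In this assay compound 3 gives > 10000 nM as a limit and not a number. No step can be read among compound 1, compound 2 and compound 3, and the series is still described only by a single limit: the limit of > 10000 nM in this assay, at which 3 of the 3 values shown sit.

The compounds shown leave open how strong each one truly is, and whether changing the group on the carbonyl carbon alters that strength at all.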